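This account rests on a few compounds, and the source may have more. Where it says the series, first, only, none or still open, it means among the compounds named here.

Measured so far in a functional assay on brain (Rattus norvegicus, strain Wistar) for inhibition; a lower number here means a stronger inhibitor, a higher number a weaker inhibitor:
compound 1 `COc1ccc2c(c1)OC/C(=C\c1ccc(O)cc1)C2=O`: > 100000 nM (a limit of the assay, not a number)
compound 2 `COc1ccc2c(c1)OC/C(=C\c1cc(OC)c(O)c(OC)c1)C2=O`: 11000 nM
compound 3 `COc1ccc2c(c1)OC/C(=C\c1ccc(O)c(O)c1)C2=O`: 12100 nM

For the measured compounds named here, compound 3 and compound 2 lie within the scatter of each other, and these are the only two actual numbers. Going by the values given here, the one measured step is an at least 8.2-fold lower number from compound 1 to compound 3 (0.91 log units; beyond the scatter), with hydroxy in place of hydrogen on an aromatic carbon.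

Compound 4 `CCCOc1ccc2c(c1)OC/C(=C\c1ccc(O)c(O)c1)C2=O` keeps everything in compound 3 except for one change, methoxy to propoxy: ethyl in place of hydrogen on a saturated chain carbon bound to an oxygen on an aromatic ring. Among the compounds with values here, no measured step covers this change. The step to compound 3 concerns a different group, so it gives no size for this one. The expectation therefore rests on compound 3 at 12100 nM, with no shift beyond the scatter expected in this assay and no direction favoured, though the uncertainty is wide. The expected step is a 1.2-fold lower number from compound 3 to compound 4 (0.08 log units; within the scatter). For compound 4 the estimated value is 10000 nM, with an expected range of 3000 nM to 40000 nM.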

Compound 4, half-maximal inhibitory concentration: 11400 nM
Compound 4: middle estimate off by 1.1-fold (0.06 log units), on the low side; measured number inside the range.
By their numbers in this assay, from the lowest: compounds 2, 4 and 3 (each within the scatter of the next). At a limit, above all of these: compound 1.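

In this assay, the change from methoxy to propoxy gives a 1.1-fold lower number from compound 3 to compound 4 (0.03 log units; within the scatter), so ethyl in place of hydrogen on this saturated chain carbon leaves the number within the scatter. Compounds 1, 2 and 3 all carry methoxy here and so say nothing about this position, whereas compound 4 shows that a propoxy group can stand in its place while the two hydroxy groups of compound 3 are kept. The only limit in the set remains that of compound 1, which is a limit of the assay and not a number: the limit of > 100000 nM in this assay, at which 1 of the 4 values shown sits.

Still open, from the compounds shown here alone, is whether a longer chain, or an amine or a carboxylic acid at the end of the chain, would move the number beyond the scatter. Also open, going by these compounds, is whether an at least 8.2-fold lower number from compound 1 to compound 3 (0.91 log units; beyond the scatter) would carry over to the propoxy series.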